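A Ring Swap at the Chain End of Compound 3

The source may report more compounds than this note shows. Statements on the series, on what has been measured and on what is new or still open speak of the compounds shown alone.

In a functional assay on MCF7 cells (Homo sapiens) for antiproliferative activity, read by MTT assay, with a stated time of 72 h (on this read-out higher numbers stand for weaker inhibition and lower numbers for stronger inhibition), compound 1 `CCN(CC)CCn1cccc1/C=N/NC(=O)Nc1ccc(Oc2ccnc3[nH]ccc23)cc1` has "not determined" (no result reported), compound 2 `CN(C)CCCn1cccc1/C=N/NC(=O)Nc1ccc(Oc2ccnc3[nH]ccc23)cc1` gives 9140 nM and compound 3 `O=C(N/N=C/c1cccn1CCCN1CCCCC1)Nc1ccc(Oc2ccnc3[nH]ccc23)cc1` gives 4690 nM. Among the measured compounds shown here, compound 3 therefore stands level with compound 2, the only other number available. Compound 4 `CN1CCN(CCCn2cccc2/C=N/NC(=O)Nc2ccc(Oc3ccnc4[nH]ccc34)cc2)CC1` carries 4-methylpiperazin-1-yl in place of piperidin-1-yl on a saturated chain carbon, three bonds along the chain from an aromatic nitrogen. For the measured compounds named here, one measured step bears on this place, a 1.9-fold lower number from compound 2 to compound 3 (0.29 log units; within the scatter), so no shift beyond the scatter is expected, though a single step is thin evidence. The expected step is a 1.2-fold higher number from compound 3 to compound 4 (0.07 log units; within the scatter). For compound 4 the estimated value in this assay is 5500 nM, with an expected range of 2500 nM to 12000 nM.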

Compound 4, half-maximal inhibitory concentration: 4280 nM
The estimate for compound 4 lay 1.3-fold (0.11 log units) above the measured number, within the range that was stated.
By their numbers in this assay, from the lowest: compounds 4, 3 and 2 (each within the scatter of the next, the first and the last beyond it).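

With 4-methylpiperazin-1-yl in place of piperidin-1-yl, this assay shows a 1.1-fold lower number from compound 3 to compound 4 (0.04 log units; within the scatter), so these two ring groups stand level at this place. Among the compounds shown here, measured against dimethylamino, 4-methylpiperazin-1-yl gives the first step here to pass the scatter, a 2.1-fold lower number from compound 2 to compound 4 (0.33 log units; beyond the scatter), although the margin is modest and piperidin-1-yl stayed within it. Nothing available accounts for this small difference. Going by these compounds, whether a morpholin-4-yl group at the chain end would stand level with these rings remains open. So does the effect of a longer chain carrying 4-methylpiperazin-1-yl.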